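The compounds below may be only part of what the source reports. "The series", "measured", "known", "first", "only" and "open" are said of these compounds alone.

Measured in an ADME assay on WI-38 cells (Homo sapiens) for cytotoxicity, read by sulforhodamine B assay, with a stated time of 24 h; a higher number here means a weaker inhibitor, a lower number a stronger inhibitor:

- compound 1 `N=c1oc2ccccc2cc1C(=O)N/N=C1\C(=O)Nc2ccc(S(=O)(=O)N3CCOCC3)cc21`: 132000 nM
- compound 2 `O=C1Nc2ccc(S(=O)(=O)N3CCOCC3)cc2/C1=N/c1ccc(Br)cc1`: 372000 nM
- compound 3 `Cc1ccc(S(=O)(=O)N/N=C2\C(=O)Nc3ccc(S(=O)(=O)N4CCOCC4)cc32)cc1`: 261000 nM

Compound 3, at 261000 nM, stands between the other two numbers and lies within the usual scatter of each, so the data do not separate it from either one. The next structure, compound 4 `O=C1Nc2ccc(S(=O)(=O)N3CCOCC3)cc2/C1=N/Nc1ccccc1`, differs from compound 3 in one place: phenyl in place of (4-methylphenyl)sulfonyl on an amine nitrogen. Put simply, phenyl takes the place of (4-methylphenyl)sulfonyl on an amine nitrogen.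

For the measured compounds named here, no two measured compounds differ in just one place, so no measured step shows what a single change of this kind does. Going by the values given here, the only guide is the spread of the three values, which run from compound 1 at 132000 nM to compound 2 at 372000 nM. A shift beyond the scatter is therefore not expected, and any drift would most likely be towards a slightly lower number. The expected change is a 1.3-fold lower number from compound 3 to compound 4 (0.12 log units; within the scatter). For compound 4 the estimated value is 200000 nM, with an expected range of 85000 nM to 450000 nM.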

Compound 4, half-maximal inhibitory concentration: 262000 nM
For compound 4 the middle estimate is 1.3-fold (0.12 log units) below the measured one, and the stated range covers the measured number.
By their numbers in this assay, from the lowest: compounds 1, 3, 4 and 2 (each within the scatter of the next, the first and the last beyond it).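

In this assay, phenyl in place of (4-methylphenyl)sulfonyl on an amine nitrogen gives a 1.0-fold higher number from compound 3 to compound 4 (0.00 log units; within the scatter) and so shows that this much larger swap, which removes the sulfonyl group and both of its hydrogen-bond acceptors, leaves the two compounds inseparable in this test of toxicity to cells. Anilino in place of 4-bromophenyl on a double-bonded nitrogen gives a 1.4-fold lower number from compound 2 to compound 4 (0.15 log units; within the scatter) and adds a second comparison that the data cannot separate. Nothing at hand explains either result.

As far as these compounds go, what remains open is how a group of a different kind would behave at this amine nitrogen, such as a short alkyl chain like methyl in place of the aromatic ring. A carboxylic acid or an amine carried on the phenyl ring of compound 4 is equally untested among the compounds shown.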